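The source may hold more compounds than are shown below. What is called first, only, known or untested is meant among the compounds shown, and "the series" means these compounds.

Of the compounds shown here, two that share a core have been measured. Compound 1, `OCc1cn(Cc2cn(-c3ccccc3)nc2-c2ccc(Cl)cc2)nn1`, carries a phenyl group on an aromatic nitrogen of that core; in a functional assay on U-937 cells (Homo sapiens) for inhibition, read by ELISA, with stated times of 1 h and 24 h (a higher number here means a weaker inhibitor, a lower number a stronger inhibitor), compound 1 gives 6230 nM. Compound 2, `Cc1ccc(-n2cc(Cn3cc(CO)nn3)c(-c3ccccc3)n2)cc1C`, carries a 3,4-dimethylphenyl group at that place; in this assay compound 2 gives 7720 nM. Compound 2 thus holds the higher of the two numbers, but its number lies within the usual scatter of that of compound 1, so the two cannot be told apart on this evidence.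

Compound 3, `OCc1cn(Cc2cn(-c3ccccc3)nc2-c2ccccc2)nn1`, has not yet been measured. It differs from compound 2 in one place: phenyl in place of 3,4-dimethylphenyl on an aromatic nitrogen. Among the compounds with values here, no measured pair shows this change on its own, so no step can be read off from the numbers at hand. Compound 1 already carries a phenyl on that nitrogen, and its value in this assay sits close to that of compound 2. On that basis the change is expected to bring, for compound 3, a step of a 1.2-fold lower number from compound 2 to compound 3 (0.07 log units; within the scatter), nothing beyond the scatter. Compound 3 is therefore estimated at 6500 nM in this assay, within a range from 2500 nM to 16000 nM.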

Compound 3, half-maximal inhibitory concentration: 8120 nM
The estimate for compound 3 lay 1.2-fold (0.10 log units) below the measured number; the range from low to high includes it.
By their numbers in this assay, from the lowest: compounds 1, 2 and 3 (each within the scatter of the next).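

Within the data shown here, compound 3 gives the first direct reading of phenyl in place of 3,4-dimethylphenyl on the aromatic nitrogen: in this assay the change produces a 1.1-fold higher number from compound 2 to compound 3 (0.02 log units; within the scatter) and so does not move the number detectably. Compound 3 also isolates a second change, hydrogen in place of chloro on an aromatic carbon, which gives a 1.3-fold higher number from compound 1 to compound 3 (0.12 log units; within the scatter) and likewise cannot be told from repeat-measurement noise. Among these compounds, then, neither the two methyl groups nor the chloro group makes a measurable difference at its position, and no measurement at hand offers an explanation for this.

Both changes are small swaps among hydrogen, methyl and chloro on a phenyl ring, so the compounds shown leave open whether a larger or different group at these places, such as an amine, a carboxylic acid or a longer alkyl chain, would shift the number beyond the scatter. They also leave open how much the hydroxymethyl group contributes, since it stays the same in all three compounds.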